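A Pyridyl in Place of a Fluorophenyl

This account rests on a few compounds, and the source may have more. Where it says the series, first, only, none or still open, it means among the compounds named here.

Compound 2 `Cc1c(O)ccc2c1[C@H](Cn1cc(-c3ccc(F)cc3)nn1)[C@@]13CC(=O)[C@@](C)(CC[C@@H]21)C3` was tested in a functional assay on SW480 cells (Homo sapiens) for cytotoxicity, read by MTT assay, with a stated time of 4 days; a lower number here means a stronger inhibitor, a higher number a weaker inhibitor. There compound 2 reaches only the limit of the assay, at > 20000 nM, so no number is known for it. Compound 1 `C=C1C[C@]23C[C@@]1(O)CC[C@H]2c1ccc(O)c(C)c1[C@@H]3Cn1cc(-c2ccccn2)nn1`, which also carries a pyridin-2-yl but on a different core, likewise gives only a limit, > 20000 nM. Compound 3 `C=C1C(=O)[C@]23C[C@@]1(O)CC[C@H]2c1ccc(O)c(C)c1[C@@H]3Cn1cc(-c2ccccc2)nn1`, carrying a plain phenyl, gives 260 nM. Compound 4 `Cc1c(O)ccc2c1[C@H](Cn1cc(-c3ccccn3)nn1)[C@@]13CC(=O)[C@@](C)(CC[C@@H]21)C3` is compound 2 with pyridin-2-yl in place of 4-fluorophenyl on an aromatic carbon. Among the measured compounds shown here, no measured pair isolates this change. Compound 2 stands at the limit, a position shared by two of the three values shown (the limit of > 20000 nM in this assay, at which 2 of the 3 values shown sit). The step from compound 2 to compound 4 is expected to be none beyond the scatter, a step that the limit leaves unreadable from compound 2 to compound 4. Compound 4 is estimated at 30000 nM, within 8000 nM to 100000 nM.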

Compound 4, half-maximal inhibitory concentration: > 20000 nM
Compound 4: only a limit was reported; the forecaster's own chance of this, stated with the estimate: 75%; the middle value lies beyond the limit too.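

Compound 2 and compound 4 both give only a limit, so no step can be read between them: the limit of > 20000 nM in this assay, at which 3 of the 4 values shown sit. The compounds shown leave open which of pyridin-2-yl and 4-fluorophenyl gives the stronger inhibitor on this core.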